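A few compounds are considered here, and "the series" means these few. Any claim that something is new, unique, unknown or untested is made for them only; others in the source may bear on it.

Compound 3 `O=C(COc1cccc2ccccc12)N/N=C/c1ccccc1Cl` gives the highest number of the three compounds measured in an ADME assay on MT4 cells (Homo sapiens) for cytotoxicity, read by MTT assay, with a stated time of 4 days (on this read-out lower numbers stand for higher toxicity in this test and higher numbers for lower toxicity in this test), at 56.2 ug/mL. Compound 1 `O=C(COc1cccc2ccccc12)N/N=C/c1ccc(O)cc1` gives 26.5 ug/mL in this assay, and compound 2 `O=C(COc1cccc2ccccc12)N/N=C/c1ccccc1[N+](=O)[O-]` gives 12.2 ug/mL. The two steps that lead to compound 3 are a 2.1-fold higher number from compound 1 to compound 3 (0.33 log units; beyond the scatter) and a 4.6-fold higher number from compound 2 to compound 3 (0.66 log units; beyond the scatter). Compound 4 `CSc1ccc(/C=N/NC(=O)COc2cccc3ccccc23)cc1` has not yet been measured in this assay. Its difference from compound 3 is 4-(methylsulfanyl)phenyl in place of 2-chlorophenyl on a carbon with a double bond to nitrogen. Neither measured step involves the 4-(methylsulfanyl)phenyl group, so no direct comparison exists; what the two steps do show is that exchanging the aryl group on the carbon with a double bond to nitrogen moved the number by modest amounts in both cases. A step of similar modest size is therefore expected here, and with compound 3 already at the top of the three numbers, the expected direction is toward lower numbers rather than further upward. The step from compound 3 to compound 4 in this assay is estimated as a 1.9-fold lower number from compound 3 to compound 4 (0.27 log units; within the scatter). Compound 4 is expected to give about 30 ug/mL in this assay, within a range from 12 ug/mL to 75 ug/mL.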

Compound 4, half-maximal cytotoxic concentration: 68.3 ug/mL
Beside the measured number, compound 4's estimate is 2.3-fold (0.36 log units) below it, and the stated range covers the measured number.
By their numbers in this assay, from the lowest: compound 2; then compound 1; then compounds 3 and 4 (each within the scatter of the next).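

In this assay, the comparison of 2-chlorophenyl with 4-(methylsulfanyl)phenyl on a carbon with a double bond to nitrogen gives a 1.2-fold higher number from compound 3 to compound 4 (0.08 log units; within the scatter), so these two groups cannot be told apart here, whereas both earlier steps at this place lay beyond the scatter. With methylsulfanyl in place of hydroxy on an aromatic carbon, the result is a 2.6-fold higher number from compound 1 to compound 4 (0.41 log units; beyond the scatter), which shows that a number at this level does not require a chloro group. Nothing available explains either step.

Among the compounds shown, no single group appears at two places on the aromatic ring, so the identity of a group and its place remain unseparated. As far as these compounds go, it also remains open whether an amine, a carboxylic acid or a longer chain in place of methylsulfanyl would keep the number at this level.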